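The compounds below may be only part of what the source reports. "The series", "measured", "known", "first", "only" and "open" are said of these compounds alone.

Going by the values given here, in an assay on isolated protein for inhibition of DNA topoisomerase 1 (Homo sapiens), with a stated time of 30 min, tested at 100 uM (a higher number here means a stronger effect of the compound at the concentration tested, a lower number a weaker effect), compound 1 `Oc1cccc(-c2cc(-c3ccccc3)cc(-c3ccccc3)n2)c1` gives 12.9%, the lowest of the two numbers measured so far. Among the compounds with values here, compound 2 `Oc1cccc(-c2cc(-c3ccccc3)cc(-c3ccsc3)n2)c1` gives 75.8%, and the step of a number 62.9 percentage points higher from compound 1 to compound 2 (beyond the scatter) is the only measured step, but it changes a different part of the molecule, thiophen-3-yl in place of phenyl on an aromatic carbon. Compound 3 `Oc1ccc(-c2cc(-c3ccccc3)cc(-c3ccccc3)n2)cc1` has not yet been measured. 4-hydroxyphenyl in place of 3-hydroxyphenyl on an aromatic carbon Here a 3-hydroxyphenyl leaves and a 4-hydroxyphenyl enters, at the carbon next to the ring nitrogen of the shared core. Within the data shown here, no measured step changes this group, so nothing measured bears directly on this change, and the large step seen between compound 1 and compound 2 cannot be carried over. Without such guidance, the expected step of a number 2.1 percentage points higher from compound 1 to compound 3 (within the scatter) is none beyond the scatter, though the range has to stay wide. For compound 3 the estimate in this assay is 15%, between 0% and 45%.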

Compound 3, a percentage reported as inhibition, at one concentration (the size of the read-out at that concentration, not a potency): 52.9%
Beside the measured number, compound 3's estimate is 37.9 percentage points below it; the whole stated range lies below it.
By their numbers in this assay, from the lowest: compound 1; then compound 3; then compound 2.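

Moving the hydroxyl around its ring is enough to change the result in this assay: the swap of 3-hydroxyphenyl for 4-hydroxyphenyl gives a number 40 percentage points higher from compound 1 to compound 3 (beyond the scatter) even though the two compounds contain the same atoms, joined differently. This carbon of the shared core, next to the ring nitrogen, is therefore a second place where a single change shifts the read-out, and here the placement of one group within the substituent counts, not only the identity of the ring. Nothing shown explains why the 4-hydroxyphenyl group gives the higher number.

Going by these compounds, whether the hydroxyl itself is needed remains open, and a 4-methoxyphenyl or 4-aminophenyl group at this carbon would address that. On these data alone, it is also open whether 4-hydroxyphenyl and thiophen-3-yl would add up in one molecule.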